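The source may hold more compounds than are shown below. What is called first, only, known or untested is meant among the compounds shown, and "the series" means these compounds.

Compound 3 `Clc1ccc(OCc2nc3ccccc3n2CCCC2CCCCN2)cc1` holds the lowest number of the three measured in an assay on isolated protein for binding affinity to Neuropeptide Y receptor type 1 (Homo sapiens) (on this read-out higher numbers stand for weaker inhibition and lower numbers for stronger inhibition), where compound 3 gives 3230 nM. Compound 1 `Clc1ccc(OCc2nc3ccccc3n2CCC2CCCCN2)cc1` gives 7860 nM, and compound 2 `Clc1ccc(OCc2nc3ccccc3n2CCCN2CCCCC2)cc1` gives 7020 nM. The step of a 2.4-fold lower number from compound 1 to compound 3 (0.39 log units; beyond the scatter) and the step of a 2.2-fold lower number from compound 2 to compound 3 (0.34 log units; beyond the scatter) are both modest, while the step of a 1.1-fold lower number from compound 1 to compound 2 (0.05 log units; within the scatter) lies within the scatter. Compound 4 `Clc1ccc(OCc2nc3ccccc3n2CCCC2CCNCC2)cc1` has the same atoms as compound 3, joined differently: piperidin-4-yl in place of piperidin-2-yl on a saturated chain carbon, three bonds along the chain from an aromatic nitrogen. The measured steps that bear on this are the two in which only the way the six-membered non-aromatic ring is joined to the chain changes: a 2.2-fold lower number from compound 2 to compound 3 (0.34 log units; beyond the scatter) was modest, and a 1.1-fold lower number from compound 1 to compound 2 (0.05 log units; within the scatter) showed nothing beyond the scatter. Re-joining this ring has so far moved the number by little or by a modest amount, and no step points to a large change in either direction. For compound 4 the expected step is a 1.1-fold higher number from compound 3 to compound 4 (0.03 log units; within the scatter), meaning no clear movement beyond the scatter. Compound 4 is therefore estimated at 3500 nM, with a range from 1300 nM to 9000 nM.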

Compound 4, inhibition constant: 980 nM
Beside the measured number, compound 4's estimate is 3.6-fold (0.55 log units) above it; the measured number lies below the stated range.
By their numbers in this assay, from the lowest: compound 4; then compound 3; then compounds 2 and 1 (each within the scatter of the next).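

Where the ring joins the chain turns out to matter at this place: in this assay, with the chain length held, piperidin-4-yl in place of piperidin-2-yl gives a 3.3-fold lower number from compound 3 to compound 4 (0.52 log units; beyond the scatter) and is a clear gain rather than a neutral re-joining. Against piperidin-1-yl on the same chain, the change gives a 7.2-fold lower number from compound 2 to compound 4 (0.86 log units; beyond the scatter), and against the shorter-chain compound it gives an 8.0-fold lower number from compound 1 to compound 4 (0.90 log units; beyond the scatter), so these two steps are larger than any seen among the first three compounds, though both still rate as modest, and compound 4 now holds the lowest number of the set. Nothing measured here says why the piperidin-4-yl ring gives the lower number.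

Still open, from the compounds shown here alone, is how a piperazine ring in the same place would compare in this assay. Also open, going by these compounds, is whether a methyl group on the ring nitrogen of piperidin-4-yl, or a longer chain carrying that ring, would lower the number further.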